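One Ring Exchanged: What Compound 3 Might Show

This account rests on a few compounds, and the source may have more. Where it says the series, first, only, none or still open, it means among the compounds named here.

Compound 1 `O=S(=O)(c1cc(Cl)cc(Cl)c1)c1cnc2c(F)cccc2c1-c1cccc(Cl)c1`: 1.2 mL/min
Compound 2 `O=S(=O)(c1ccc(F)c(F)c1)c1cnc2c(F)cccc2c1-c1ccc(F)cc1`: 0.78 mL/min

Both were tested in an ADME assay on microsomes from liver (Homo sapiens) for metabolic stability, tested at 2.5 uM; a higher number here means faster removal of the compound, a lower number slower removal. Compound 2 stands at the lower of the two numbers, but its gap to compound 1 lies within the scatter of repeated measurements, so the two cannot be told apart. Compound 3 `O=S(=O)(c1ccc(F)c(F)c1)c1cnc2c(F)cccc2c1-c1cccc(Cl)c1` has not been measured yet. It differs from compound 2 in one place: 3-chlorophenyl in place of 4-fluorophenyl on an aromatic carbon. Within the data shown here, no step between measured compounds matches this change, so nothing here points in a direction; the expectation is no step beyond the scatter. For compound 3 the estimate is 1 mL/min, between 0.5 mL/min and 2 mL/min. The step of a 1.3-fold higher number from compound 2 to compound 3 (0.11 log units; within the scatter) implied by this estimate is expected to stay within the scatter.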

Compound 3, intrinsic clearance in a liver preparation (reported as CLH), per the amount of preparation that the assay uses: 1.13 mL/min
Estimate against measurement, compound 3: 1.1-fold (0.05 log units) below; low and high end bracket the measured number.
By their numbers in this assay, from the lowest: compounds 2, 3 and 1 (each within the scatter of the next).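

In this assay, putting 3-chlorophenyl in place of 4-fluorophenyl gives a 1.4-fold higher number from compound 2 to compound 3 (0.16 log units; within the scatter), so this exchange at this position cannot be told apart from no change at all. On the sulfonyl sulfur, 3,4-difluorophenyl in place of 3,5-dichlorophenyl gives a 1.1-fold lower number from compound 1 to compound 3 (0.03 log units; within the scatter), and this exchange cannot be told apart from no change either. Nothing measured here offers a reason for these numbers. From the compounds shown here alone, every group exchanged so far is a phenyl ring carrying chlorine or fluorine, so it remains open whether an amine or a carboxylic acid at either place would shift the number beyond the scatter.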